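Aryl substituent change from compound 2 to compound 3

This account rests on a few compounds, and the source may have more. Where it says the series, first, only, none or still open, it means among the compounds named here.

Measured so far in an assay on PMNL cells for inhibition of Polyunsaturated fatty acid 5-lipoxygenase (Homo sapiens), read by HPLC, with stated times of 15 min and 10 min; on this read-out lower numbers stand for stronger inhibition and higher numbers for weaker inhibition: compound 1 `CCC(=O)Nc1ccc(C2=NC(=O)/C(=C/c3ccc(OC)cc3)S2)cc1` gives 760 nM; compound 2 `COc1ccc(/C=C2\SC(c3ccc(C(=O)c4ccccc4)cc3)=NC2=O)cc1` gives 150 nM.

Within the data shown here, compound 2 has the lowest of the two numbers, with compound 1 the only neighbour, separated by the step of a 5.1-fold lower number from compound 1 to compound 2 (0.70 log units; beyond the scatter). Compound 3 `CCCOc1ccc(C2=NC(=O)/C(=C/c3ccc(OC)cc3)S2)cc1` is the next candidate; it differs from compound 2 by propoxy in place of benzoyl on an aromatic carbon. Among the measured compounds shown here, the only measured step that bears on this is the one from compound 1 to compound 2, which also swapped the group on that same aromatic carbon and was modest in size but beyond the scatter. It shows that this position does move the read-out, yet it gives no direct reading for propoxy, a group with no ring in place of the benzoyl. The direction is therefore uncertain; a return toward the number of compound 1 seems as likely as holding the level of compound 2, so a weaker-than-compound-2 outcome is expected, with the step from compound 2 to compound 3 estimated at a 2.7-fold higher number from compound 2 to compound 3 (0.43 log units; beyond the scatter). For compound 3 in this assay the expected value is 400 nM, with a range from 120 nM to 1500 nM.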

Compound 3, half-maximal inhibitory concentration: 210 nM
Compound 3: middle estimate off by 1.9-fold (0.28 log units), on the high side; the range from low to high includes it.
By their numbers in this assay, from the lowest: compounds 2 and 3 (each within the scatter of the next); then compound 1.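

In this assay, replacing benzoyl with propoxy on this aromatic carbon, para to a large group, gives a 1.4-fold higher number from compound 2 to compound 3 (0.15 log units; within the scatter), so a group with no ring reads the same as benzoyl within the scatter and the benzoyl ring is not required to keep the number of compound 2. The earlier step, a 5.1-fold lower number from compound 1 to compound 2 (0.70 log units; beyond the scatter), could have been read as specific to benzoyl, but a 3.6-fold lower number from compound 1 to compound 3 (0.56 log units; beyond the scatter) shows that a second, quite different group also separates from propanoylamino beyond the scatter, leaving compound 1 apart from the other two compounds. No measurement at hand bears on why these groups read as they do.

The compounds shown leave open whether a longer chain such as hexyloxy, or a shorter one such as methoxy, would stay level with compound 2 and compound 3 at this position. They also leave open whether a free amine or a carboxylic acid there would read closer to compound 1, and whether the methoxy group on the other aromatic ring can be exchanged without moving the number.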